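Swapping a selenium group for 2-aminoethoxy

A few compounds are considered here, and "the series" means these few. Any claim that something is new, unique, unknown or untested is made for them only; others in the source may bear on it.

Compound 1 `Cc1nc(N(C)c2ccc([Se]C#N)c(C)c2)c2ccccc2n1`: 17 nM
Compound 2 `COc1ccc(N(C)c2nc(C)nc3ccccc23)cc1[Se]C`: 11 nM
Compound 3 `C[Se]c1ccc(N(C)c2nc(C)nc3ccccc23)cc1Cl`: 4 nM

These three compounds share one core and were all tested in a functional assay on RKO cells (Homo sapiens) for inhibition, read by MTT assay, with a stated time of 48 h; on this read-out higher numbers stand for weaker inhibition and lower numbers for stronger inhibition. Compound 2, at 11 nM, stands second highest of the three numbers. It cannot be told apart from compound 1, since their gap lies within the usual scatter of repeat measurements. Compound 3 has a clearly lower number than compound 2, which means stronger inhibition.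

The next compound to be tested is compound 4 `COc1ccc(N(C)c2nc(C)nc3ccccc23)cc1OCCN`, and it differs from compound 2 in one place: a group of 4 heavy atoms (2 carbon, 1 nitrogen, 1 oxygen; no ring) in place of a group of 2 heavy atoms (1 carbon, 1 selenium; no ring), on an aromatic carbon. The incoming 2-aminoethoxy sits on an aromatic carbon, ortho to a methoxy group and meta to a large group.

Among the measured compounds shown here, no measured pair here shows what such a swap does. Every measured number, from compound 3 at 4 nM to compound 1 at 17 nM, comes from a compound carrying selenium, and compound 4 carries none. A step towards weaker inhibition, beyond the scatter, therefore seems the likelier outcome, though this is a cautious expectation and its size is uncertain. The expected change is an 11-fold higher number from compound 2 to compound 4 (1.04 log units; beyond the scatter). In this assay, the estimated value for compound 4 is 120 nM, with an expected range of 20 nM to 700 nM.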

Compound 4, half-maximal inhibitory concentration: 343 nM
The estimate for compound 4 lay 2.9-fold (0.46 log units) below the measured number, within the range that was stated.
By their numbers in this assay, from the lowest: compound 3; then compounds 2 and 1 (each within the scatter of the next); then compound 4.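

In this assay, putting 2-aminoethoxy in place of the group of one carbon and one selenium moves the number a 31-fold higher number from compound 2 to compound 4 (1.49 log units; beyond the scatter) and marks a large step towards weaker inhibition, well beyond the scatter of repeat measurements. Among the compounds shown here, this is the first direct view of this position, on an aromatic carbon ortho to a methoxy group, and it shows that what sits there matters a great deal for inhibition in these cells. For the compounds shown here, it also gives the first number for a compound without selenium, and that compound still inhibits, though clearly less well than compound 2, while nothing at hand speaks to why the number rose.

The compounds shown leave open how much of this step belongs to the departing selenium group and how much to the incoming chain, since the two changes arrive together in a single swap. A plain methoxy, a 2-hydroxyethoxy chain without the amine, or a longer chain ending in a dimethylamine at the same position would begin to pull these two parts apart.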